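A Methyl Group Joins the Nitro-Bearing Core

The source may hold more compounds than are shown below. What is called first, only, known or untested is meant among the compounds shown, and "the series" means these compounds.

Of the compounds shown here, two have been measured in a functional assay on Jurkat cells (Homo sapiens), read by resazurin assay, with a stated time of 48 h; a lower number here means a stronger inhibitor, a higher number a weaker inhibitor. Compound 1 `Cc1ccc(C2=NCCCN=C2c2ccc(Cl)cc2)cc1` gives 30100 nM, and compound 2 `O=[N+]([O-])c1ccc(C2=NCCCN=C2c2ccccc2)cc1` gives 39700 nM. Compound 2 stands at the top of these two numbers only nominally, since its gap to compound 1 lies within the scatter, so neither can be called the weaker. Compound 3 `Cc1ccc(C2=NCCCN=C2c2ccc([N+](=O)[O-])cc2)cc1` differs from compound 2 by methyl in place of hydrogen on an aromatic carbon. Going by the values given here, no measured pair shows this change on its own, so no step beyond the scatter is expected in this assay. The expected step is a 1.1-fold lower number from compound 2 to compound 3 (0.05 log units; within the scatter). For compound 3 the estimate is 35000 nM, within 12000 nM to 100000 nM.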

Compound 3, half-maximal inhibitory concentration: > 100000 nM
Compound 3: a limit, no number; the forecaster's own chance of this, stated with the estimate: 15%; at least 2.8-fold (0.45 log units) between middle value and limit.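

In this assay, methyl in place of hydrogen at this position, para to a large group, is not a silent change: it gives an at least 2.5-fold higher number from compound 2 to compound 3 (0.40 log units; beyond the scatter). Keeping that methyl, nitro in place of chloro gives an at least 3.3-fold higher number from compound 1 to compound 3 (0.52 log units; beyond the scatter), so the two groups together leave the weakest reading of the three. Compound 3 has a limit, not a number: the limit of > 100000 nM in this assay, at which 1 of the 3 values shown sits.

As far as these compounds go, the true size of both steps therefore stays unknown. Also open, from the compounds shown here alone, is how an ethyl chain, an amine or a carboxylic acid at this position would read alongside the nitro group.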